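The source may hold more compounds than are shown below. What is called first, only, known or untested is meant among the compounds shown, and "the series" means these compounds.

Measured compounds:
compound 1 `COc1cc(-c2cc(/C=C/C(=O)c3ccc(N)cc3)[nH]n2)cc(OC)c1OC`, a functional assay on NCI-H23 cells (Homo sapiens) for inhibition, read by sulforhodamine B assay, with a stated time of 48 h (on this read-out lower numbers stand for stronger inhibition of growth and higher numbers for weaker inhibition of growth), 2480 nM
compound 2 `COc1cc(-c2cc(/C=C/C(=O)c3ccc(Cl)c(Cl)c3)[nH]n2)cc(OC)c1OC`, 23400 nM

Among the measured compounds shown here, compound 2 gives the higher of the two numbers; the only step measured so far, a 9.4-fold higher number from compound 1 to compound 2 (0.97 log units; beyond the scatter), separates it from compound 1, so compound 2 stands as the weaker of the pair by a margin beyond the scatter.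

Compound 3 `COc1ccc(C(=O)/C=C/c2cc(-c3cc(OC)c(OC)c(OC)c3)n[nH]2)cc1OC` differs from compound 2 by 3,4-dimethoxyphenyl in place of 3,4-dichlorophenyl on a carbonyl carbon. For the measured compounds named here, no measured step exchanges a dichlorophenyl for a dimethoxyphenyl; the one step that bears on the same carbonyl carbon, a 9.4-fold higher number from compound 1 to compound 2 (0.97 log units; beyond the scatter), shows that the aryl group on this carbon moves the number by a modest amount beyond the scatter. A group with two hydrogen-bond acceptors but no donor sits between the two measured cases, so a moderate fall in this assay is expected, a 2.9-fold lower number from compound 2 to compound 3 (0.47 log units; beyond the scatter), without reaching compound 1. Compound 3 is therefore estimated at 8000 nM, range 2000 nM to 32000 nM.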

Compound 3, concentration for 50% growth inhibition: 2150 nM
Beside the measured number, compound 3's estimate is 3.7-fold (0.57 log units) above it; measured number inside the range.
By their numbers in this assay, from the lowest: compounds 3 and 1 (each within the scatter of the next); then compound 2.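

On the carbonyl carbon in this assay, the exchange of 3,4-dichlorophenyl for 3,4-dimethoxyphenyl gives an 11-fold lower number from compound 2 to compound 3 (1.04 log units; beyond the scatter), a large step. The exchange of 4-aminophenyl for 3,4-dimethoxyphenyl gives a 1.2-fold lower number from compound 1 to compound 3 (0.06 log units; within the scatter), so among these compounds a hydrogen-bond donor on the entering aryl group is not needed for a number of this size, and 3,4-dichlorophenyl alone stands apart. No measurement at hand accounts for the gap between the dichlorophenyl and dimethoxyphenyl compounds.

Open, from the compounds shown here alone, is whether the weaker number follows from the chlorines themselves or from having both of them, which 4-chlorophenyl, 4-methoxyphenyl or plain phenyl on the carbonyl carbon would help to separate. Also open, going by these compounds, is how a dimethylamino group or a carboxylic acid on this aryl ring would read, and whether the pattern carries over to other cell lines.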